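The compounds below may be only part of what the source reports. "The series", "measured", "known", "first", "only" and "open" are said of these compounds alone.

Compound 1 `N#CC1=C(N)Oc2c(c3nc4ccccc4nc3c3ccccc23)C12C(=O)N(Cc1cnnn1-c1ccc(F)cc1)c1ccccc12`: in a functional assay on HepG2 cells (Homo sapiens) for antiproliferative activity, read by MTT assay, with a stated time of 48 h (a higher number here means a weaker inhibitor, a lower number a stronger inhibitor), compound 1 gives > 50000 nM, which is a limit of the assay rather than a number.
Compound 2 `COc1ccccc1-n1nncc1CN1C(=O)C2(C(C#N)=C(N)Oc3c2c2nc4ccccc4nc2c2ccccc32)c2ccccc21`: in this assay compound 2 gives > 50000 nM, likewise a limit of the assay.
Compound 3 `N#CC1=C(N)Oc2c(c3nc4ccccc4nc3c3ccccc23)C12C(=O)N(Cc1cnnn1-c1cccc(S(N)(=O)=O)c1)c1ccccc12`: in this assay compound 3 gives 21500 nM.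

For the measured compounds named here, compound 3 therefore stands as the only compound with a measured number; the other two values are limits. The step from compound 1 to compound 2 cannot be read because of the limit of > 50000 nM in this assay, at which 2 of the 3 values shown sit. The steps toward compound 3 are readable: an at least 2.3-fold lower number from compound 1 to compound 3 (0.36 log units; beyond the scatter) and an at least 2.3-fold lower number from compound 2 to compound 3 (0.36 log units; beyond the scatter). Going by the values given here, both point the same way, with the 3-sulfamoylphenyl group giving the only number measured.

Compound 4 `Cc1cc(C)cc(-n2nncc2CN2C(=O)C3(C(C#N)=C(N)Oc4c3c3nc5ccccc5nc3c3ccccc43)c3ccccc32)c1` is not yet measured. It differs from compound 3 in one place: 3,5-dimethylphenyl in place of 3-sulfamoylphenyl on an aromatic nitrogen. The group that enters carries no hydrogen-bond donors or acceptors, which puts it closer to the 4-fluorophenyl of compound 1 and the 2-methoxyphenyl of compound 2 than to the 3-sulfamoylphenyl of compound 3. On that basis the number for compound 4 is expected to rise again, roughly undoing the step seen in an at least 2.3-fold lower number from compound 1 to compound 3 (0.36 log units; beyond the scatter), so the expected step is a 2.8-fold higher number from compound 3 to compound 4 (0.45 log units; beyond the scatter). Compound 4 is estimated at 60000 nM, within a range from 20000 nM to 200000 nM, with a fair chance that this assay reports only a limit.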

Compound 4, half-maximal inhibitory concentration: > 50000 nM
Compound 4: a limit, no number (the forecaster's own chance of this, stated with the estimate: 65%); the middle value is on the limit's open side.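

In this assay, putting 3,5-dimethylphenyl in place of 3-sulfamoylphenyl on the aromatic nitrogen gives an at least 2.3-fold higher number from compound 3 to compound 4 (0.36 log units; beyond the scatter). For the compounds shown here, this adds a third aryl group without the sulfamoyl group that fails to give a number, so within these four compounds a substituted phenyl ring at this place is not enough on its own, and compound 3 remains the only compound with a measured value. The steps among compound 1, compound 2 and compound 4 cannot be read because all three rest on the same limit: the limit of > 50000 nM in this assay, at which 3 of the 4 values shown sit.

On these data alone, it remains open whether the sulfamoyl group is special or whether another group on the phenyl ring, such as an amine or a carboxylic acid, would also give a number. Compound 3 gives 21500 nM, and whether any group at this place can bring the number much lower is also unanswered.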